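This account rests on a few compounds, and the source may have more. Where it says the series, first, only, none or still open, it means among the compounds named here.

Measured so far:
compound 1 `C=CC(=O)Nc1cccc(-n2c(-c3nc(-c4cnn(C5CCN(C)CC5)c4)cnc3N)nc3ccccc32)c1F` — < 10000 nM
compound 2 `C=CC(=O)Nc1cccc(-n2c(-c3nc(-c4cnn(C5CCN(C)CC5)c4)cnc3N)nc3ccncc32)c1` — 540000 nM
compound 3 `C=CC(=O)Nc1cccc(-n2c(-c3nc(-c4cnn(CCN5CCN(C)CC5)c4)cnc3N)nc3ccccc32)c1` — 30000 nM

In a physicochemical assay for solubility, at pH 7.4 (a higher number here means a more soluble compound, a lower number a less soluble compound), compound 3 gives 30000 nM, the lower of the two numbers reported; compound 2 gives a higher number, a gap beyond the usual scatter. For compound 1 the assay reports only a limit, (the limit of < 10000 nM in this assay, at which 1 of the 3 values shown sits), and not a number. Compound 4 `C=CC(=O)Nc1cccc(-n2c(-c3nc(-c4cnn(C5CCN(C(=O)CO)CC5)c4)cnc3N)nc3ccccc32)c1` has not been measured in this assay. It differs from compound 3 in one place: 1-((hydroxymethyl)carbonyl)piperidin-4-yl in place of 2-(4-methylpiperazin-1-yl)ethyl on an aromatic nitrogen. Among the measured compounds shown here, no pair among the measured compounds shows this change, so the size of the step is open. From compound 3 to compound 4 a decrease in solubility is expected, a 3.0-fold lower number from compound 3 to compound 4 (0.48 log units; beyond the scatter). For compound 4 the estimate in this assay is 10000 nM, with a range from 2000 nM to 60000 nM.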

Compound 4, solubility: < 10000 nM
Compound 4: no number, only a limit; the forecaster's own chance of this, stated with the estimate: 35%; the middle value lies on the limit itself.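

In this assay, among the compounds shown here, putting 1-((hydroxymethyl)carbonyl)piperidin-4-yl in place of 2-(4-methylpiperazin-1-yl)ethyl on the aromatic nitrogen gives an at least 3.0-fold lower number from compound 3 to compound 4 (0.47 log units; beyond the scatter) as the first step that can be read at this position. It shows that changing this group alone can move the result beyond the scatter. Compound 4 has a limit and not a number: the limit of < 10000 nM in this assay, at which 2 of the 4 values shown sit.

As far as these compounds go, the full size of the step therefore stays open. So does the outcome with a 2-(morpholin-4-yl)ethyl group or an unsubstituted piperidin-4-yl amine on that nitrogen.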